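The compounds below may be only part of what the source reports. "The series", "measured", "known", "first", "only" and "open" are said of these compounds alone.

In a functional assay, read by spectrophotometry, with a stated time of 3 min (a lower number here means a stronger inhibitor, a higher number a weaker inhibitor), so far:
- compound 1 `O=c1cc(/C=N\c2ccccc2O)c2c(OCc3ccccc3)cc(OCc3ccccc3)cc2o1` gives 7760 nM
- compound 2 `O=c1cc(/C=N\c2ccc(O)cc2)c2ccc(OCc3ccccc3)cc2o1` gives 64500 nM

Of these two, compound 2 has the higher number and is the weaker inhibitor, and its gap to compound 1 lies beyond the scatter. Compound 3 `O=c1cc(-c2nc3ccccc3[nH]2)c2ccc(OCc3ccccc3)cc2o1` has not yet been measured. Relative to compound 2 it shows (a group of 9 heavy atoms (7 carbon, 2 nitrogen; one five-membered aromatic ring with 2 hetero atoms, one six-membered aromatic ring of carbon only) in place of a group of 9 heavy atoms (7 carbon, 1 nitrogen, 1 oxygen; one six-membered aromatic ring of carbon only), on an aromatic carbon), with 1H-benzimidazol-2-yl entering on an aromatic carbon opposite the ring oxygen. Within the data shown here, no measured pair differs in one place, so the data do not show the size of such a change. A modest move toward a lower number is expected in this assay, resting only on compound 2 at 64500 nM having the higher of the two values. The expected move is a 2.2-fold lower number from compound 2 to compound 3 (0.33 log units; beyond the scatter) (an estimate with wide uncertainty). For compound 3 the estimated value is 30000 nM (expected range 6000 nM to 150000 nM).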

Compound 3, half-maximal inhibitory concentration: "not active" (no number reported)
The entry for compound 3 holds no number; no gap can be computed for the estimate.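

Among these compounds, compound 3 is reported as not active, with no number, and no step from compound 2 to compound 3 can be read. No measured evidence bears on this result. The compounds shown leave open what any single change on the shared core does to inhibition.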